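A few compounds are considered here, and "the series" means these few. Any claim that something is new, unique, unknown or untested is made for them only; others in the source may bear on it.

Measured so far in an assay on LX2 cells for inhibition of COL1A1 promoter (Homo sapiens), read by a luciferase reporter, with a stated time of 24 h, tested at 50 uM; a lower number here means a weaker effect, a higher number a stronger effect of the compound at the concentration tested:
Compound 1 `CN(C)c1ccc2c(=O)c(C(=O)Nc3cc(F)cc(F)c3)cn(-c3ccc(OCCCCCCC[N+]45CCN(CC4)CC5)c(Cl)c3)c2n1`: 20.5%
Compound 2 `Cc1ccc(-n2cc(C(=O)Nc3cc(F)cc(F)c3)c(=O)c3ccc(N(C)C)nc32)cc1OCCCCCCC[N+]12CCN(CC1)CC2`: 9.71%
Compound 3 `CN(C)c1ccc2c(=O)c(C(=O)Nc3cc(F)cc(F)c3)cn(-c3ccc(Cl)c(OCCCCCCC[N+]45CCN(CC4)CC5)c3)c2n1`: 18.7%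

Compound 2 stands lowest of the three numbers; its nearest neighbour is compound 3, within the scatter, and the furthest is compound 1, beyond the scatter. Among the measured compounds shown here, the one single-point step among the measured compounds, a number 9 percentage points higher from compound 2 to compound 3 (within the scatter), lies within the scatter.

Compound 4 `Cc1ccc(-n2cc(C(=O)Nc3cc(F)cc(F)c3)c(=O)c3ccc(N(C)C)nc32)cc1OCCCCCCC[N+]1(C)CCCC1` differs from compound 2 by a group of 6 heavy atoms (5 carbon, 1 nitrogen; one five-membered non-aromatic ring with 1 hetero atom) in place of a group of 8 heavy atoms (6 carbon, 2 nitrogen; 2 six-membered non-aromatic rings with 2 hetero atoms each), on a saturated chain carbon, seven bonds along the chain from an oxygen on an aromatic ring. No measured pair changes this group, so nothing in the set bears directly on the step; the only step shown concerns a different place and is itself within the scatter. A step of no more than the scatter is therefore expected in this assay, in either direction. Compound 4 is estimated at 12%, range 0% to 28%, an expected step of a number 2.3 percentage points higher from compound 2 to compound 4 (within the scatter).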

Compound 4, a percentage reported as inhibition, at one concentration (the size of the read-out at that concentration, not a potency): 55.9%
Estimate against measurement, compound 4: 43.9 percentage points below; measured number outside the range, above it.
By their numbers in this assay, from the lowest: compounds 2, 3 and 1 (each within the scatter of the next, the first and the last beyond it); then compound 4.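

Among the compounds shown here, the end of the chain is the first place where a single change goes clearly beyond the scatter: in this assay the swap gives a number 46.2 percentage points higher from compound 2 to compound 4 (beyond the scatter) with the charged group as the only difference. Both groups carry net charge +1, so net charge alone does not separate them. Nothing in the data given accounts for the step.

Still open, as far as these compounds go, is whether a piperidinium, a morpholinium or a plain tertiary amine at the chain end would hold this number. Also open, from the compounds shown here alone, is how the group of compound 4 behaves with chloro in place of methyl, as in compound 3.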